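This account rests on a few compounds, and the source may have more. Where it says the series, first, only, none or still open, it means among the compounds named here.

Compound 1 `Cc1cc(C)cc(S(=O)(=O)c2c(C(=O)N[C@H]3CCN(Cc4ccccc4C#N)C3)[nH]c3ccc(Cl)cc23)c1` and compound 3 `Cc1cc(C)cc(S(=O)(=O)c2c(C(=O)NC3CN(Cc4ccccc4C#N)C3)[nH]c3ccc(Cl)cc23)c1` are built alike in most of their parts, but the difference between the two cores is not broken down here. In an ADME assay on MT4 cells (Homo sapiens) for cytotoxicity, read by MTT assay, with a stated time of 5 days (on this read-out higher numbers stand for lower toxicity in this test and lower numbers for higher toxicity in this test), compound 1 reaches only the limit of the test, > 228000 nM. Compound 3 likewise reaches only a limit in this assay, > 234000 nM. Compound 2 `Cc1cc(C)cc(S(=O)(=O)c2c(C(=O)N[C@H]3CCN(S(C)(=O)=O)C3)[nH]c3ccc(Cl)cc23)c1` is compound 1 with methylsulfonyl in place of 2-cyanobenzyl on an amine nitrogen in a ring. In this assay compound 2 gives 29900 nM, so the step of an at least 7.6-fold lower number from compound 1 to compound 2 (0.88 log units; beyond the scatter) means greater toxicity in this test. Compound 4 `Cc1cc(C)cc(S(=O)(=O)c2c(C(=O)NC3CN(S(C)(=O)=O)C3)[nH]c3ccc(Cl)cc23)c1` carries the same kind of change made on compound 3, (methylsulfonyl in place of 2-cyanobenzyl on an amine nitrogen in a ring); the place differs in that the amine nitrogen sits in a four-membered non-aromatic ring with 1 nitrogen rather than a five-membered non-aromatic ring with 1 nitrogen. Compound 1 at the limit of > 228000 nM in this assay, at which 1 of the 3 values shown sits, and compound 3 at the limit of > 234000 nM in this assay, at which 1 of the 3 values shown sits, start from alike positions. A step of similar size is therefore expected, an at least 5.8-fold lower number from compound 3 to compound 4 (0.76 log units; beyond the scatter). For compound 4 in this assay the expected value is about 40000 nM, with a range from 15000 nM to 200000 nM.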

Compound 4, half-maximal cytotoxic concentration: > 252000 nM
Compound 4: a limit, no number; the forecaster's own chance of this, stated with the estimate: 25%; at least 6.3-fold (0.79 log units) between middle value and limit.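

Compound 4 reaches only a limit of the test, not a number: the limit of > 252000 nM in this assay, at which 1 of the 4 values shown sits. Compound 3 also stands at a limit, and the step from it to compound 4 cannot be read, which means that an at least 7.6-fold lower number from compound 1 to compound 2 (0.88 log units; beyond the scatter), seen on the five-membered ring, is neither confirmed nor ruled out on the four-membered ring. What can be read is an at least 8.4-fold higher number from compound 2 to compound 4 (0.92 log units; beyond the scatter), which means lower toxicity in this test with methylsulfonyl on both cores, and this shows that the greater toxicity of compound 2 does not appear as a measured number on the four-membered ring, though it does not show how much the change itself does there.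

The compounds shown leave open how far the two cores would part with other groups on the ring nitrogen, such as an acetyl or a plain benzyl. They also leave open whether any such group on the four-membered ring would give a number rather than a limit.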